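The source may hold more compounds than are shown below. What is called first, only, known or untested is meant among the compounds shown, and "the series" means these compounds.

Measured compounds:
Compound 1, `Cc1cnc(NC(=O)CCCOc2cncc(Cl)c2)s1`, gives 0.1 h in an ADME assay on microsomes from liver (Mus musculus) for metabolic stability, read by LC-MS, using NADPH, tested at 1 uM; on this read-out higher numbers stand for a longer-lived compound and lower numbers for a shorter-lived compound.
Compound 2, `N#Cc1cnc(NC(=O)CCCOc2cccc(C(F)(F)F)c2)s1`, gives 0.517 h in this assay.

Of these two numbers in this assay, compound 2 holds the higher one, and its gap to compound 1 lies beyond the usual scatter of repeated measurements. For the measured compounds named here, the two compounds differ in several places at once, so the data give no single step that could be followed from one to the other.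

Compound 3, `N#Cc1cnc(NC(=O)CCCOc2ccccc2)s1`, has not yet been measured in this assay. It differs from compound 2 in one place only: hydrogen in place of trifluoromethyl on an aromatic carbon. Going by the values given here, no measured pair shows what this change does here, and nothing among the measured compounds bears on it directly. The step of a 1.5-fold lower number from compound 2 to compound 3 (0.17 log units; within the scatter) that is expected is therefore a modest one, leaning toward a somewhat shorter-lived compound but possibly staying within the scatter. Compound 3 is estimated to give 0.35 h in this assay, with a range from 0.12 h to 1 h.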

Compound 3, half-life in the Mus musculus assay: 0.25 h
Estimate against measurement, compound 3: 1.4-fold (0.15 log units) above, within the range that was stated.
By their numbers in the Mus musculus assay, from the lowest: compound 1; then compound 3; then compound 2.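

For the compounds shown here, the pair gives the first single-place step in the Mus musculus assay, a 2.1-fold lower number from compound 2 to compound 3 (0.32 log units; beyond the scatter), so on this aromatic carbon the compound with hydrogen holds the lower half-life of the two, by a modest margin. In a physicochemical assay for solubility, read by nephelometry, in phosphate buffer, at pH 6.5 (on this read-out lower numbers stand for lower solubility and higher numbers for higher solubility), compound 3 gives 1100 nM. In the physicochemical assay compound 2 gives < 1600 nM, which is a limit of the assay and not a number, so the step in solubility for this change cannot be read: the limit of < 1600 nM in the physicochemical assay, at which 1 of the 2 values shown sits.

The compounds shown leave open how a methoxy group or an amine on the same aromatic carbon compares with trifluoromethyl and hydrogen. They also leave open whether this step carries over to the core of compound 1, and how far this change moves solubility.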